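Replacing cyclopentylamino with isobutoxy, with no starting number

The source may report more compounds than this note shows. Statements on the series, on what has been measured and on what is new or still open speak of the compounds shown alone.

In a physicochemical assay for solubility (a higher number here means a more soluble compound, a lower number a less soluble compound), compound 3 `CS(=O)(=O)c1ccc(-n2nc(C(F)(F)F)c(C#N)c2NC2CCCC2)nc1` has the result "not determined" (no result reported) and so offers no number to start from. Compound 1 `C[C@@H]1CN(c2c(C#N)c(C(F)(F)F)nn2-c2ccc(S(C)(=O)=O)cn2)[C@H](C)CO1` gives > 200 ug/mL as a limit of the assay and not a number. Among the measured compounds shown here, compound 2 `CS(=O)(=O)c1ccc(-n2nc(C(F)(F)F)cc2NC2CCCC2)nc1` gives 25 ug/mL as the only plain number here. Compound 4 `CC(C)COc1c(C#N)c(C(F)(F)F)nn1-c1ccc(S(C)(=O)=O)cn1` is the next structure to be measured. The change isobutoxy in place of cyclopentylamino on an aromatic carbon puts isobutoxy in place of cyclopentylamino on an aromatic carbon. Within this assay no measured step shows what this swap does, so the expectation stays with compound 2 at 25 ug/mL with no change beyond the usual scatter. Compound 4 is estimated at 35 ug/mL with 8 ug/mL to 150 ug/mL as the expected range.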

Compound 4, solubility: < 25 ug/mL
Compound 4: only a limit was reported; the forecaster's own chance of this, stated with the estimate: 10%; middle value at least 1.4-fold (0.14 log units) away from the limit.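

In this assay compound 4 gives < 25 ug/mL, which is a limit of the assay and not a number. With isobutoxy on this aromatic carbon in place of the six-membered ring group of compound 1, the result is an at least 8.0-fold lower number from compound 1 to compound 4 (0.90 log units; beyond the scatter). This is the first sign that the group at this position can shift the read-out beyond the scatter, though the step rests on limits at both ends: the limit of > 200 ug/mL in this assay, at which 1 of the 4 values shown sits.

The direct swap of cyclopentylamino for isobutoxy cannot be read, as compound 3 has no reported result. On these data alone, whether a shorter ether such as methoxy, or a primary amine, on this carbon would fall nearer compound 1 or compound 4 stays open.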